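N-Methylation of the ring amide in a spiro-oxindole series

The source may hold more compounds than are shown below. What is called first, only, known or untested is meant among the compounds shown, and "the series" means these compounds.

Compound 1 `CN1C/C(=C\c2ccc(Cl)cc2)C(=O)[C@]2(C1)[C@@H](c1ccc(Cl)cc1)CN(C)[C@@]21C(=O)Nc2ccccc21` and compound 2 `CN1C/C(=C\c2ccc(Cl)cc2)C(=O)[C@]2(C1)[C@@H](c1ccc(Cl)cc1)CN(C)[C@@]21C(=O)N(C)c2ccccc21` share one core, compound 3 `Cc1ccc(/C=C2\CN(C)C[C@@]3(C2=O)[C@@H](c2ccc(C)cc2)CN(C)[C@@]32C(=O)Nc3ccccc32)cc1` and the as yet unmeasured compound 4 `Cc1ccc(/C=C2\CN(C)C[C@@]3(C2=O)[C@@H](c2ccc(C)cc2)CN(C)[C@@]32C(=O)N(C)c3ccccc32)cc1` another; how the two cores differ is not broken down here. In a functional assay on the whole organism (strain Wister albino) for inhibition, with Rattus norvegicus as the target, read by paw edema, with a stated time of 1 h, at a dose of 50 mg/kg by the intraperitoneal route (a higher number here means more inhibition at the dose given (going by the name of the read-out), a lower number less inhibition), compound 1 gives 83.1%, compound 2 gives 82.3%, and compound 3 gives 69.2%, the lowest of the three, with both other numbers lying beyond the scatter above it.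

Within the first core the only change is methyl in place of hydrogen on an amide-type nitrogen in a ring. The step it made, a number 0.8 percentage points lower from compound 1 to compound 2 (within the scatter), is within the scatter, so the methyl on the ring amide nitrogen left the read-out in this assay essentially unchanged.

Compound 4 carries the same change on the second core, (methyl in place of hydrogen on an amide-type nitrogen in a ring), and the place is described in identical words for both pairs. Within the data shown here, since the only measured instance of this change, compound 1 to compound 2, moved the number by a number 0.8 percentage points lower from compound 1 to compound 2 (within the scatter), the step from compound 3 to compound 4 is expected to be similarly small, about a number 0.7 percentage points lower from compound 3 to compound 4 (within the scatter). Compound 4 is therefore estimated at 68.5%, with a likely range from 58% to 78%.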

Compound 4, a percentage reported as inhibition, in the whole organism at one dose (the size of the read-out at that dose, not a potency): 53.5%
The estimate for compound 4 lay 15 percentage points above the measured number; measured number below the stated range.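

In this assay, methyl in place of hydrogen on an amide-type nitrogen in a ring gives a number 15.7 percentage points lower from compound 3 to compound 4 (beyond the scatter), so on the core of compound 3 this change is not the silent one it was on the core of compound 1. The result of the change therefore did not transfer between the two cores, and a step read on one core is a poor guide to the other: the same change on two cores in this assay, a number 0.8 percentage points lower (within the scatter) from compound 1 to compound 2 and a number 15.7 percentage points lower (beyond the scatter) from compound 3 to compound 4, 14.9 percentage points apart, beyond the scatter of two such steps

This shows a dependence on the core for these two pairs only; it does not show which of the differences between the cores is responsible, nor which of the two steps would be the more typical on a further core.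

From the compounds shown here alone, whether a longer chain such as ethyl, or a benzyl group, on the same nitrogen would track the small step or the large one stays open. Also open, going by these compounds, is how the methyl would behave on a core carrying methoxy or fluoro groups.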